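Efficacy at an adrenergic receptor: from compound 2 to compound 3

The source may hold more compounds than are shown below. What is called first, only, known or untested is meant among the compounds shown, and "the series" means these compounds.

Measured so far:
compound 1, `CCS(=O)(=O)Nc1cccc(Cc2c[nH]cn2)c1C`: 69%
compound 2, `CN(c1cccc2c1CCCC2c1c[nH]cn1)S(C)(=O)=O`: 79%

In a functional assay on Urethra with Alpha-1A adrenergic receptor (Oryctolagus cuniculus) as the target (on this read-out lower numbers stand for smaller maximal responses and higher numbers for larger maximal responses), compound 2 gives 79%, and compound 1 gives 69%; the two values lie within the usual scatter of each other, so neither is set apart. Compound 3, `CC(C)S(=O)(=O)Nc1cccc2c1CCCC2c1c[nH]cn1`, is not yet measured. It differs from compound 2 by (isopropylsulfonyl)amino in place of methyl(methylsulfonyl)amino on an aromatic carbon. Among the measured compounds shown here, no step between measured compounds is known, so no direction can be read from the data; a step beyond the scatter is not expected. Compound 3 is estimated to give 75%, in the range 60% to 90%, which would mean a number 4 percentage points lower from compound 2 to compound 3 (within the scatter).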

Compound 3, largest response reached (reported as efficacy), in percent of the reference or control that the assay uses: 74%
Beside the measured number, compound 3's estimate is 1 percentage points above it; the range from low to high includes it.
By their numbers in this assay, from the lowest: compounds 1, 3 and 2 (each within the scatter of the next).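

In this assay, replacing methyl(methylsulfonyl)amino with (isopropylsulfonyl)amino on this aromatic carbon gives a number 5 percentage points lower from compound 2 to compound 3 (within the scatter) and so does not set the two compounds apart. At this place, the maximal response therefore does not separate them, even though the entering group carries a hydrogen-bond donor that the leaving group lacks. No measurement at hand explains this result.

On these data alone, the groups on the nitrogen and on the sulfur change together, so the effect of each alone stays open. As far as these compounds go, how an amine or a carboxylic acid would behave here is also open.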